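A few compounds are considered here, and "the series" means these few. Any claim that something is new, unique, unknown or untested is made for them only; others in the source may bear on it.

Three compounds built on a shared core differ only in the aryl group on an amine nitrogen in a ring. In a functional assay on CHO cells with adenosine receptor A1 (Homo sapiens) as the target, read by cAMP accumulation and immunoassay, with a stated time of 6 min, tested at 10 uM (a higher number here means a weaker effect of the compound at the concentration tested, a lower number a stronger effect), compound 1 `Nc1scc(CN2CCN(c3ccc(F)cc3Cl)CC2)c1C(=O)c1ccc(Cl)cc1` gives -70%, compound 2 `Nc1scc(CN2CCN(c3cccc(F)c3)CC2)c1C(=O)c1ccc(Cl)cc1` gives -82%, and compound 3 `Nc1scc(CN2CCN(c3ccccc3F)CC2)c1C(=O)c1ccc(Cl)cc1` gives -15%. Compound 3 therefore stands highest of the three, which means the weakest effect: the step of a number 55 percentage points higher from compound 1 to compound 3 (beyond the scatter) and the step of a number 67 percentage points higher from compound 2 to compound 3 (beyond the scatter) are both beyond the scatter and both large.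

Compound 4 `Nc1scc(CN2CCN(c3c(F)cc(F)cc3F)CC2)c1C(=O)c1ccc(Cl)cc1` has not been measured. It differs from compound 3 in one place: 2,4,6-trifluorophenyl in place of 2-fluorophenyl on an amine nitrogen in a ring. The two measured steps that change the group at this same place are the ones just named, a number 55 percentage points higher from compound 1 to compound 3 (beyond the scatter) and a number 67 percentage points higher from compound 2 to compound 3 (beyond the scatter), and both were large. Among the compounds with values here, the only measured compound whose phenyl carries more than one halogen, compound 1, gives -70%. Within the data shown here, on that basis a large step downward, toward stronger effect, is expected for compound 4, namely a number 35 percentage points lower from compound 3 to compound 4 (beyond the scatter), though with only three measured compounds the range is wide. The estimate for compound 4 in this assay is -50%, expected to fall between -85% and -10%.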

Compound 4, a percentage reported as activity, at one concentration (the size of the read-out at that concentration, not a potency): -78%
Compound 4: middle estimate off by 28 percentage points, on the high side; low and high end bracket the measured number.
By their numbers in this assay, from the lowest: compounds 2, 4 and 1 (each within the scatter of the next, the first and the last beyond it); then compound 3.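

The step from the 2-fluorophenyl group to 2,4,6-trifluorophenyl (a number 63 percentage points lower from compound 3 to compound 4 (beyond the scatter)) shows, in this assay, that the fluorine of the 2-fluorophenyl group does not by itself fix the weak result, since compound 4 keeps a fluorine in that name position, carries two more, and has a much stronger effect. The two other steps (a number 4 percentage points higher from compound 2 to compound 4 (within the scatter) and a number 8 percentage points lower from compound 1 to compound 4 (within the scatter)) place compound 4 level with each of those compounds, so three different halogen patterns on this phenyl now read alike and compound 3 alone stands apart. No data at hand explain why this change has so large an effect.

As far as these compounds go, all four phenyl groups carry only fluorine or chlorine, so what a methoxy group or a nitrile would do at this place stays open. Each read-out also gives the size of the effect at one concentration, so the potency of these compounds stays open too.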